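Hydroxy for methyl on the side chain of compound 3

The compounds below may be only part of what the source reports. "The series", "measured", "known", "first", "only" and "open" are said of these compounds alone.

The study covers bisaziridinyl quinone cores bearing different groups on one double-bonded ring carbon. Compound 1 `CC1=C(N2CC2)C(=O)C(Cc2ccccc2)=C(N2CC2)C1=O` gives 4.26 in a functional assay on L1210 cells (Mus musculus), with a stated time of 1 days; on this read-out lower numbers stand for lower potency and higher numbers for higher potency (the scale is a negative logarithm). Compound 2 `CC1=C(N2CC2)C(=O)C(N2CC2)=C(N2CC2)C1=O` gives 5.69, a rise of a number 1.43 log units higher from compound 1 to compound 2 (beyond the scatter). Compound 3 `CCC(OC)C1=C(N2CC2)C(=O)C(C)=C(N2CC2)C1=O` gives 4.84; it stands second highest of the three, with compound 1 nearest and a number 0.58 log units higher from compound 1 to compound 3 (beyond the scatter) below it, and compound 2 furthest, the step of a number 0.85 log units lower from compound 2 to compound 3 (beyond the scatter) setting the gap.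

Compound 4 `COC(CO)C1=C(N2CC2)C(=O)C(C)=C(N2CC2)C1=O` is unmeasured. It differs from compound 3 by hydroxy in place of methyl on a saturated chain carbon, two bonds along the chain from a double-bonded ring carbon and an oxygen on a saturated carbon. None of the three measured steps touches this part of the molecule: all three exchange the whole group on the double-bonded ring carbon, whereas here the aziridin-1-yl groups and the methoxy-bearing chain are kept and only the chain end is altered. The large and modest steps seen so far therefore give no direct guide, and nothing in the data points to a change of either sign. The estimate for compound 4 is thus a step of a number 0.06 log units higher from compound 3 to compound 4 (within the scatter) from compound 3, expected to lie within the scatter. Compound 4 is estimated at 4.9, expected between 4.3 and 5.5.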

Compound 4, logarithm of the reciprocal of the active concentration, log(1/C): 5.27
Compound 4: the middle estimate sits 0.37 log units below what was measured; the measured number falls inside the stated range.
By their numbers in this assay, from the lowest: compound 1; then compound 3; then compound 4; then compound 2.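

In this assay, the end of the chain proves able to shift the read-out on its own: with the aziridin-1-yl groups and the methoxy-bearing chain carbon kept, hydroxy in place of methyl gives a number 0.43 log units higher from compound 3 to compound 4 (beyond the scatter) for a single-atom exchange, whereas every earlier step replaced the whole group on the double-bonded ring carbon. The 2-hydroxy-1-methoxyethyl group still falls short of aziridin-1-yl on that carbon, with a number 0.42 log units lower from compound 2 to compound 4 (beyond the scatter) on that comparison, but it stands well clear of benzyl, with a number 1.01 log units higher from compound 1 to compound 4 (beyond the scatter) on the other. Nothing at hand accounts for the rise from methyl to hydroxy.

As far as these compounds go, whether the gain is tied to the hydroxy itself, or would also appear with an amine or a carboxylic acid at the chain end, remains open, as does the effect of a longer chain carrying the hydroxy. Also open, from the compounds shown here alone, is whether the same exchange would count with ethoxy in place of the methoxy on the chain, as both compound 3 and compound 4 carry methoxy there.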